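Swapping the group on the triazole carbon of the core

The source may hold more compounds than are shown below. What is called first, only, known or untested is meant among the compounds shown, and "the series" means these compounds.

Compound 3 `COc1nc2ccc(Br)cc2cc1C(c1ccccc1)n1cc(CO)nn1` gives 15% in an ADME assay on PANC-1 cells (Homo sapiens) for cytotoxicity, read by sulforhodamine B assay, with a stated time of 48 h, tested at 10 uM; a higher number here means more inhibition at the concentration tested (going by the name of the read-out), a lower number less inhibition. Of the three numbers measured, that of compound 3 is the second highest, though it sits within the scatter of the other two: compound 1 `CCCCCCCCc1cn(C(c2ccccc2)c2cc3cc(Br)ccc3nc2OC)nn1` gives 12.1% and compound 2 `CCOC(=O)c1cn(C(c2ccccc2)c2cc3cc(Br)ccc3nc2OC)nn1` gives 15.4% in this assay. The steps of a number 2.9 percentage points higher from compound 1 to compound 3 (within the scatter) and a number 0.4 percentage points lower from compound 2 to compound 3 (within the scatter) both alter the group on the aromatic carbon of the five-membered aromatic ring with 3 nitrogen and both stay within the scatter, as does a number 3.3 percentage points higher from compound 1 to compound 2 (within the scatter). Compound 4 `COc1nc2ccc(Br)cc2cc1C(c1ccccc1)n1cc(C2CC2)nn1` alters the same position: cyclopropyl in place of hydroxymethyl on an aromatic carbon. All three measured steps at this position bear on it and none left the scatter, so no step beyond the scatter is expected in this assay for the change from compound 3 to compound 4. The expected step is a number 1 percentage points lower from compound 3 to compound 4 (within the scatter). Compound 4 is therefore estimated to give 14% in this assay, with a range from 5% to 25%.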

Compound 4, a percentage reported as inhibition, at one concentration (the size of the read-out at that concentration, not a potency): 21.8%
Beside the measured number, compound 4's estimate is 7.8 percentage points below it; the range from low to high includes it.
By their numbers in this assay, from the lowest: compounds 1, 3, 2 and 4 (each within the scatter of the next).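

Cyclopropyl brings a three-membered ring to the aromatic carbon of the five-membered aromatic ring with 3 nitrogen, and in this assay the result reads a number 6.8 percentage points higher from compound 3 to compound 4 (within the scatter), a number 6.4 percentage points higher from compound 2 to compound 4 (within the scatter) and a number 9.7 percentage points higher from compound 1 to compound 4 (within the scatter). Among these compounds, with octyl, ethoxycarbonyl, hydroxymethyl and cyclopropyl, the position has now carried a long chain, a ring and groups with and without hydrogen-bond donors, and no step among compounds 1 to 4 leaves the scatter. Nothing available explains these numbers.

From the compounds shown here alone, whether an amine or a carboxylic acid at this position would give a step beyond the scatter remains open. Also open, going by these compounds, are how changes elsewhere on the shared core would read and how these compounds compare in potency, since the numbers come from a single concentration.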